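The compounds below may be only part of what the source reports. "The series", "measured", "known", "first", "only" and "open" are said of these compounds alone.

In a functional assay on MDA-MB-231 cells (Homo sapiens) for antiproliferative activity, read by MTT assay, with a stated time of 72 h (a higher number here means a weaker inhibitor, a lower number a stronger inhibitor), compound 1 (`CC(C)c1cccc(NC(=O)CCc2cccc3c2B(O)OC3)c1`) gives 1600 nM and compound 2 (`C#Cc1cccc(NC(=O)CCc2cccc3c2B(O)OC3)c1`) gives 1600 nM as well, so the step between them shows no change at the digits printed from compound 1 to compound 2 (within the scatter) and no real difference. Compound 3 (`COc1cc(OC)cc(-c2cccc(NC(=O)CCc3cccc4c3B(O)OC4)c2)c1`) stands lowest of the three at 40 nM and is the strongest inhibitor so far. The two steps that reach it are large (a 40-fold lower number from compound 1 to compound 3 (1.60 log units; beyond the scatter)) and (a 40-fold lower number from compound 2 to compound 3 (1.60 log units; beyond the scatter)). Compound 4 (`O=C(CCc1cccc2c1B(O)OC2)Nc1cccc(-c2ccc(C(F)(F)F)cc2)c1`) has 4-(trifluoromethyl)phenyl in place of 3,5-dimethoxyphenyl on an aromatic carbon. For the measured compounds named here, no measured step exchanges one such ring-bearing group for another, so the data do not give the size of this change directly. Compound 4 still carries an aromatic ring at that place, as compound 3 does, so a return to the level of compound 1 (1600 nM) is not expected. A modest rise in the number is the likelier outcome, and a step of a 2.5-fold higher number from compound 3 to compound 4 (0.40 log units; beyond the scatter) is expected in this assay on this reasoning. The estimate for compound 4 is 100 nM (30 nM to 400 nM).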

Compound 4, half-maximal inhibitory concentration: 510 nM
For compound 4 the middle estimate is 5.1-fold (0.71 log units) below the measured one; measured number above the stated range.
By their numbers in this assay, from the lowest: compound 3; then compound 4; then compounds 1 and 2 (each within the scatter of the next).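

In this assay, carrying an aromatic ring at this place does not by itself give the level of compound 3: 4-(trifluoromethyl)phenyl and 3,5-dimethoxyphenyl each hold 10 heavy atoms and one six-membered aromatic ring, yet the exchange is large (a 13-fold higher number from compound 3 to compound 4 (1.11 log units; beyond the scatter)). The ring-bearing compound 4 still improves modestly on the smaller groups (a 3.1-fold lower number from compound 1 to compound 4 (0.50 log units; beyond the scatter); a 3.1-fold lower number from compound 2 to compound 4 (0.50 log units; beyond the scatter)), so the groups at this place now fall into three levels rather than two. No measurement bears on what lies behind these differences.

Open, from the compounds shown here alone, is whether the two methoxy groups, their placement or the absence of trifluoromethyl matters most, as the two rings differ in both substituent and pattern. Also open, going by these compounds, is how a pyridine ring, or a phenyl ring bearing an amine or a carboxylic acid, would fare at this place.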